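This account rests on a few compounds, and the source may have more. Where it says the series, first, only, none or still open, it means among the compounds named here.

Compound 1 `CC(C(=O)NCc1ccc(C(F)(F)F)nc1NC1CCCCC1)c1ccc(NS(C)(=O)=O)c(F)c1` gives 260 nM
Compound 2 `Cc1ccc(Nc2nc(C(F)(F)F)ccc2CNC(=O)C(C)c2ccc(NS(C)(=O)=O)c(F)c2)cc1C` gives 1160 nM
Compound 3 `CC(C(=O)NCc1ccc(C(F)(F)F)nc1NCc1ccccc1)c1ccc(NS(C)(=O)=O)c(F)c1` gives 203 nM

In a functional assay on CHO-K1 cells for antagonist activity at transient receptor potential cation channel subfamily V member 1 (Homo sapiens), read by FLIPR (a higher number here means a weaker inhibitor, a lower number a stronger inhibitor), compound 3 gives 203 nM, the lowest of the three numbers. The closest neighbour is compound 1: the move a 1.3-fold lower number from compound 1 to compound 3 (0.11 log units; within the scatter) stays within the scatter, so the two cannot be told apart. The move a 5.7-fold lower number from compound 2 to compound 3 (0.76 log units; beyond the scatter) is beyond the scatter, as is a 4.5-fold higher number from compound 1 to compound 2 (0.65 log units; beyond the scatter).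

Compound 4 `CC(C(=O)NCc1ccc(C(F)(F)F)nc1NCc1ccc(Cl)cc1)c1ccc(NS(C)(=O)=O)c(F)c1` differs from compound 3 in one place: chloro in place of hydrogen on an aromatic carbon. All three measured steps swap the whole group on the nitrogen attached to the aromatic ring of the shared core, from cyclohexyl to benzyl to 3,4-dimethylphenyl; none of them adds a single atom onto the benzyl ring, so they bear on this step only loosely. The benzyl and cyclohexyl compounds sit close together, and only the 3,4-dimethylphenyl group moved the number beyond the scatter. A step of a 1.1-fold lower number from compound 3 to compound 4 (0.05 log units; within the scatter) is therefore expected, within the scatter in either direction. For compound 4 the estimate is 180 nM, with a range from 70 nM to 450 nM.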

Compound 4, half-maximal inhibitory concentration: 414 nM
Beside the measured number, compound 4's estimate is 2.3-fold (0.36 log units) below it, and the stated range covers the measured number.
By their numbers in this assay, from the lowest: compounds 3, 1 and 4 (each within the scatter of the next, the first and the last beyond it); then compound 2.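

In this assay, chloro on an aromatic carbon of the benzyl ring, para to a large group, is the only single-atom change among these compounds, and it gives a modest loss of potency (a 2.0-fold higher number from compound 3 to compound 4 (0.31 log units; beyond the scatter)). The 4-chlorobenzyl group still outperforms 3,4-dimethylphenyl (a 2.8-fold lower number from compound 2 to compound 4 (0.45 log units; beyond the scatter)), but it cannot be told apart from cyclohexyl (a 1.6-fold higher number from compound 1 to compound 4 (0.20 log units; within the scatter)). No measurement at hand explains why chloro at this place weakens inhibition.

Still open, going by these compounds, is how fluoro, methoxy or an amine at this same place would compare with chloro. Whether chloro elsewhere on the benzyl ring would give a similar step also remains unanswered.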